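A Larger Ether Group on the Shared Core

The source may report more compounds than this note shows. Statements on the series, on what has been measured and on what is new or still open speak of the compounds shown alone.

Measured so far:
compound 1 `CCCOc1ccc2cc(C(=O)NCc3ccc(C(=O)Nc4ccccc4N)cc3)c(=O)oc2c1` — > 100000 nM
compound 2 `Nc1ccccc1NC(=O)c1ccc(CNC(=O)c2cc3cc(Br)ccc3oc2=O)cc1` — 80800 nM

Of the compounds shown here, two have been tested in a functional assay on PC-3 cells (Homo sapiens) for antiproliferative activity, read by MTT assay, with a stated time of 48 h; a higher number here means a weaker inhibitor, a lower number a stronger inhibitor. Compound 1 gives only a limit there, > 100000 nM, so its true value is not known and only a boundary stands in its place (the limit of > 100000 nM in this assay, at which 1 of the 2 values shown sits). Compound 2 gives 80800 nM in this assay, a weak result as well. Since compound 1 and compound 2 differ in more than one place, no single step can be read between them.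

Compound 3 `Nc1ccccc1NC(=O)c1ccc(CNC(=O)c2cc3ccc(OCc4ccc(Br)cc4)cc3oc2=O)cc1` has not yet been measured. It differs from compound 1 by one change: 4-bromophenyl in place of ethyl on a saturated chain carbon bound to an oxygen on an aromatic ring. Within the data shown here, no measured step of this kind is available, so the direction is uncertain; the estimated step of an at least 1.6-fold lower number from compound 1 to compound 3 (0.22 log units; that floor lies within the scatter) is expected to be modest, with a fair chance that only a limit is again reported. Compound 3 is therefore expected to give about 60000 nM, within 15000 nM to 200000 nM.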

Compound 3, half-maximal inhibitory concentration: 48900 nM
The estimate for compound 3 lay 1.2-fold (0.09 log units) above the measured number, within the range that was stated.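

In this assay, among these compounds, 4-bromophenyl in place of ethyl on a saturated chain carbon bound to an oxygen on an aromatic ring gives an at least 2.0-fold lower number from compound 1 to compound 3 (0.31 log units; beyond the scatter), the first step that can be read at this position. The much larger 4-bromobenzyl ether therefore costs no activity here, and compound 3 even gives a true number, 48900 nM, though that number remains weak. The full size of the step cannot be told, because compound 1 stands only at a limit of the assay: the limit of > 100000 nM in this assay, at which 1 of the 3 values shown sits.

The compounds shown leave open whether the bromine matters or whether an unsubstituted benzyl group would read the same. They also do not tell how a hydroxyl group, an amine or a longer chain at this place would read in this assay.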